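Methoxy to Hydroxy: Expecting a Fourth Compound's Growth Inhibition

The source may report more compounds than this note shows. Statements on the series, on what has been measured and on what is new or still open speak of the compounds shown alone.

Three compounds have been measured in a functional assay on U-251 cells (Homo sapiens) for inhibition, read by sulforhodamine B assay, with a stated time of 48 h; a higher number here means a weaker inhibitor of growth, a lower number a stronger inhibitor of growth:
Compound 1 `O=C(Nc1cccc(-n2cc(-c3ccncc3)c(-c3ccc(Cl)c(O)c3)n2)c1)Nc1cccc(C(F)(F)F)c1`: 7650 nM
Compound 2 `COc1cc(-c2nn(-c3cccc(NC(=O)Nc4cccc(C(F)(F)F)c4)c3)cc2-c2ccncc2)ccc1Cl`: 1370 nM
Compound 3 `COc1cc(-c2nn(-c3cccc(NC(=O)Nc4ccc(Cl)c(C(F)(F)F)c4)c3)cc2-c2ccncc2)ccc1Cl`: 4180 nM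

Compound 2 is the point of comparison. Compound 1 is made from it by the change (hydrogen in place of methyl on an oxygen on an aromatic ring), and in this assay this gave a 5.6-fold higher number from compound 2 to compound 1 (0.75 log units; beyond the scatter), a weaker inhibitor of growth. The values of compound 1 and compound 3 are within the scatter of each other.

Compound 4 `O=C(Nc1cccc(-n2cc(-c3ccncc3)c(-c3ccc(Cl)c(O)c3)n2)c1)Nc1ccc(Cl)c(C(F)(F)F)c1` has not yet been measured. It is made from compound 3 by the change (hydrogen in place of methyl on an oxygen on an aromatic ring), described as methoxy to hydroxy on the 4-chloro-3-methoxyphenyl. This is the same change as that from compound 2 to compound 1, at a place described in the same words. The two cores differ by chloro in place of hydrogen on an aromatic carbon, which in this assay gave a 3.1-fold higher number from compound 2 to compound 3 (0.48 log units; beyond the scatter).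

Because the earlier step was a 5.6-fold higher number from compound 2 to compound 1 (0.75 log units; beyond the scatter), the step from compound 3 to compound 4 in this assay is expected to be a 4.8-fold higher number from compound 3 to compound 4 (0.68 log units; beyond the scatter), of similar size. Compound 4 is therefore estimated at 20000 nM, expected between 7000 nM and 55000 nM.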

Compound 4, concentration for total growth inhibition: 1230 nM
For compound 4 the middle estimate is 16-fold (1.21 log units) above the measured one, outside the stated range (below it).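

In this assay, the change from methoxy to hydroxy did not carry over from one core to the other, as the step of a 3.4-fold lower number from compound 3 to compound 4 (0.53 log units; beyond the scatter) runs in the opposite direction to the earlier one: the same change on two cores in this assay, a 5.6-fold higher number (0.75 log units; beyond the scatter) from compound 2 to compound 1 and a 3.4-fold lower number (0.53 log units; beyond the scatter) from compound 3 to compound 4, 19-fold (1.28 log units) apart, beyond the scatter of two such steps. The chloro change reverses in the same way, giving a 6.2-fold lower number from compound 1 to compound 4 (0.79 log units; beyond the scatter) among the hydroxy compounds, whereas it gave a higher number among the methoxy compounds: the same change on two cores in this assay, a 3.1-fold higher number (0.48 log units; beyond the scatter) from compound 2 to compound 3 and a 6.2-fold lower number (0.79 log units; beyond the scatter) from compound 1 to compound 4, 19-fold (1.28 log units) apart, beyond the scatter of two such steps. These four compounds show that the effect of each change depends on the group present at the other place, so a step measured on one core is a poor guide to the other here, but they do not show why this happens or how the change behaves on any further core.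

From the compounds shown here alone, it remains open whether a third core would follow compound 1 or compound 4 in its response to this change. Going by these compounds, it is also open how an ethoxy group or an amine at the same place on either core would compare with the methoxy and hydroxy groups.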